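The source may hold more compounds than are shown below. What is called first, only, known or untested is meant among the compounds shown, and "the series" means these compounds.

In a functional assay on HT-29 cells (Homo sapiens) for antiproliferative activity, read by MTT assay, with a stated time of 72 h (a higher number here means a weaker inhibitor, a lower number a stronger inhibitor), compound 1 `C=CC(=O)N(CC(=O)O)c1nc(-c2ccccc2)cs1` gives > 30000 nM, which is a limit of the assay. Among the measured compounds shown here, compound 2 `C=CC(=O)N(CC(=O)N1CCOCC1)c1nc(-c2ccccc2)cs1` gives 13300 nM, the only actual number so far. Compound 3 `C=CC(=O)N(CC(=O)NC1COC1)c1nc(-c2ccccc2)cs1` gives > 30000 nM, also a limit, and so stands at the limit of > 30000 nM in this assay, at which 2 of the 3 values shown sit.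

Compound 4 `C=CC(=O)N(Cc1cc(C)no1)c1nc(-c2ccccc2)cs1` has 3-methyl-1,2-oxazol-5-yl in place of (oxetan-3-yl)carbamoyl on a saturated chain carbon bound to an amide-type nitrogen. For the measured compounds named here, no measured step makes this exchange. The nearest evidence comes from changes on the carbonyl carbon: there is an at least 2.2-fold lower number from compound 1 to compound 2 (0.35 log units; beyond the scatter), and there is an at least 2.2-fold higher number from compound 2 to compound 3 (0.35 log units; beyond the scatter). There is also a step that the two limits leave unreadable from compound 1 to compound 3. These show that the number in this assay can move by a modest step in either direction, but they do not fix a direction here.

Going by the values given here, with compound 2 at 13300 nM as the only guide, a modest move to a lower number is expected. For compound 4 another limit of the assay remains quite possible. The expected step is an at least 2.3-fold lower number from compound 3 to compound 4 (0.36 log units; beyond the scatter). For compound 4 the estimate is 13000 nM, with an expected range of 4000 nM to 40000 nM.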

Compound 4, half-maximal inhibitory concentration: > 30000 nM
Compound 4: a limit, no number (the forecaster's own chance of this, stated with the estimate: 40%); at least 2.3-fold (0.36 log units) between middle value and limit.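

At the saturated chain carbon bound to an amide-type nitrogen, 3-methyl-1,2-oxazol-5-yl does not retain what the (morpholin-4-yl)carbonyl group gives, with an at least 2.2-fold higher number from compound 2 to compound 4 (0.35 log units; beyond the scatter). In this assay, compound 4 gives only a limit, so its steps to compound 1 and compound 3 cannot be read. The first group at this position without a carbonyl therefore leaves compound 2 as the only compound with an actual number, and the series remains largely at the assay limit: the limit of > 30000 nM in this assay, at which 3 of the 4 values shown sit.

As far as these compounds go, the order among compound 1, compound 3 and compound 4 remains open, as none has an actual number. Also open, from the compounds shown here alone, is whether a piperidin-1-yl or piperazin-1-yl amide, or a longer chain carrying the morpholin-4-yl amide, would give a lower number than compound 2.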